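Propyl to Allyl: A Step With No Measured Precedent

This account rests on a few compounds, and the source may have more. Where it says the series, first, only, none or still open, it means among the compounds named here.

Compound 2 `CCCNc1nc(NCc2ccc(C(=O)NC3CCN(C(=O)c4ccc(F)cc4)CC3)cc2)c2cc(C)ccc2n1` carries the higher of the two numbers measured in a functional assay on HCT-116 cells (Homo sapiens) for inhibition, read by luminescence and resazurin assay, with a stated time of 3 days (a lower number here means a stronger inhibitor, a higher number a weaker inhibitor), at 6800 nM. Going by the values given here, its only relative, compound 1 `CCCNc1nc(NCc2ccc(C(=O)NC3CCN(Cc4ccc(F)cc4)CC3)cc2)c2cc(C)ccc2n1`, gives 1600 nM in this assay, and the step of a 4.3-fold higher number from compound 1 to compound 2 (0.63 log units; beyond the scatter) is the single measured change on record. Compound 3 `C=CCNc1nc(NCc2ccc(C(=O)NC3CCN(C(=O)c4ccc(F)cc4)CC3)cc2)c2cc(C)ccc2n1` differs from compound 2 by vinyl in place of ethyl on a saturated chain carbon bound to a nitrogen on an aromatic ring. Among the compounds with values here, no measured step bears on this propylamino-to-allylamino exchange, and the data give no direction for it. Compound 3 is therefore expected to land near 6800 nM, between 2500 nM and 18000 nM. The expected step of no change at the digits printed from compound 2 to compound 3 (within the scatter) thus stays within the usual scatter.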

Compound 3, half-maximal inhibitory concentration: 6900 nM
Compound 3: the middle estimate sits 1.0-fold (0.01 log units) below what was measured, within the range that was stated.
By their numbers in this assay, from the lowest: compound 1; then compounds 2 and 3 (each within the scatter of the next).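

In this assay the change to vinyl in place of ethyl gives a 1.0-fold higher number from compound 2 to compound 3 (0.01 log units; within the scatter) and so shows that the propylamino to allylamino exchange leaves the number unchanged within the scatter. Going by these compounds alone, the earlier step concerned only the group on the amine nitrogen in a ring, so this is the first reading at this chain. Nothing measured here explains the result.

Going by these compounds, a longer chain such as butyl, or a chain ending in a hydroxyl group or an amine, remains open. So does whether the same exchange reads alike on compound 1.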